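Fluoro for Methyl on a Trimethoxy Chalcone Aryl Ketone

This account rests on a few compounds, and the source may have more. Where it says the series, first, only, none or still open, it means among the compounds named here.

Measured compounds:
Compound 1, `COc1cc(OC)c(OC)cc1/C=C/C(=O)c1ccc(C)cc1`: 42200 nM
Compound 2, `COc1cc(OC)c(OC)cc1/C=C/C(=O)c1cc(OC(C)=O)ccc1OC(C)=O`: 57900 nM
Compound 3, `COc1cc(OC)c(C(=O)/C=C/c2cc(OC)c(OC)cc2OC)c(OC)c1`: 108000 nM

Of the compounds shown here, three sharing the trimethoxy-substituted styryl ketone core have been measured in a functional assay on HeLa cells (Homo sapiens) for inhibition, read by MTT assay, with a stated time of 72 h; a lower number here means a stronger inhibitor, a higher number a weaker inhibitor. Compound 1 gives 42200 nM, and compound 2 gives 57900 nM; these two numbers lie within the scatter of each other, so no order between them can be read. Compound 3 gives 108000 nM, a higher number that lies beyond the scatter from compound 1. No pair among these three differs in only one place, so no single-point step is available to calibrate the change considered here.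

Compound 4, `COc1cc(OC)c(OC)cc1/C=C/C(=O)c1ccc(F)cc1`, differs from compound 1 in one place: fluoro in place of methyl on an aromatic carbon. The change exchanges one heavy atom for another, with no ring, donor or acceptor count altered. With nothing in the measured set speaking to this exchange, the step of a 1.1-fold lower number from compound 1 to compound 4 (0.02 log units; within the scatter) is expected to be small, in either direction, and not beyond the scatter. Compound 4 is therefore estimated at 40000 nM, with a range from 15000 nM to 110000 nM.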

Compound 4, half-maximal inhibitory concentration: 28600 nM
Beside the measured number, compound 4's estimate is 1.4-fold (0.15 log units) above it; low and high end bracket the measured number.
By their numbers in this assay, from the lowest: compounds 4, 1, 2 and 3 (each within the scatter of the next, the first and the last beyond it).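

In this assay, within the data shown here, the step of a 1.5-fold lower number from compound 1 to compound 4 (0.17 log units; within the scatter) gives the first reading of a change at a single place. On this aromatic carbon, para to a large group, the exchange of 4-methylphenyl for 4-fluorophenyl therefore produces no difference that can be told from the usual scatter, so neither group can be ranked above the other here. No measurement is available that bears on the size of this step.

The compounds shown leave open whether a group of another kind at this place, such as an amine, a carboxylic acid or a longer chain, would move the number beyond the scatter. They also leave open whether the same exchange of methyl for fluoro would give a similar step on a different core.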